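A few compounds are considered here, and "the series" means these few. Any claim that something is new, unique, unknown or untested is made for them only; others in the source may bear on it.

Compound 1 `c1ccc(-c2nnc(-c3c[nH]c4ccccc34)o2)cc1` carries a phenyl on the shared core. In a functional assay on DU-145 cells (Homo sapiens) for cytotoxicity, read by MTT assay (on this read-out lower numbers stand for stronger inhibition and higher numbers for weaker inhibition), compound 1 gives only a limit, > 1000000 nM. Compound 2 `COc1ccc(-c2nnc(-c3c[nH]c4ccccc34)o2)cc1` adds methoxy in place of hydrogen on an aromatic carbon. In this assay compound 2 likewise gives only a limit, > 1000000 nM. The step that the two limits leave unreadable from compound 1 to compound 2 is therefore unreadable, both values sitting at the limit of > 1000000 nM in this assay, at which 2 of the 2 values shown sit. Compound 3 `Cc1nnc(-c2c[nH]c3ccccc23)o1` arises by methyl in place of phenyl on an aromatic carbon. Among the compounds with values here, no measured step bears on this change, so nothing points to a size or direction in this assay beyond the scatter. Compound 3 is expected at 1000000 nM (range 300000 nM to 3000000 nM). The step of a number no higher from compound 1 to compound 3 (the limit leaves the size open) is an estimate only.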

Compound 3, half-maximal inhibitory concentration: > 1000000 nM
Compound 3: a limit, no number; the forecaster's own chance of this, stated with the estimate: 85%; the middle value sits exactly at the limit.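

Within the data shown here, compound 3, like compound 1, gives only a limit in this assay, so no step between them can be read: the limit of > 1000000 nM in this assay, at which 3 of the 3 values shown sit. The compounds shown leave open whether any group on the shared core changes the read-out in this assay.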